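Swapping a formyl for a cyanosulfanyl on a fused core

A few compounds are considered here, and "the series" means these few. Any claim that something is new, unique, unknown or untested is made for them only; others in the source may bear on it.

Going by the values given here, compound 3 `O=Cc1c(-c2ccc(F)cc2)nc2sc(Cc3ccc(Cl)cc3)nn12` is the one compound here with a real number: in a functional assay on HeLa cells (Homo sapiens) for cytotoxicity, with a stated time of 72 h (on this read-out lower numbers stand for stronger inhibition and higher numbers for weaker inhibition), compound 3 gives 20000 nM. Compound 1 `Fc1ccc(-c2cn3nc(Cc4ccc(Cl)cc4)sc3n2)cc1` reaches only a limit in this assay, > 250000 nM. Compound 2 `Fc1ccc(-c2nc3sc(Cc4ccc(Cl)cc4)nn3c2Br)cc1` likewise stops at a limit, > 250000 nM. Two steps were large, an at least 12-fold lower number from compound 1 to compound 3 (1.09 log units; beyond the scatter) and an at least 12-fold lower number from compound 2 to compound 3 (1.09 log units; beyond the scatter), while a step that the two limits leave unreadable from compound 1 to compound 2, because of the limit of > 250000 nM in this assay, at which 2 of the 3 values shown sit. Compound 4 `N#CSc1c(-c2ccc(F)cc2)nc2sc(Cc3ccc(Cl)cc3)nn12` is not yet measured; it differs from compound 3 by cyanosulfanyl in place of formyl on an aromatic carbon. Among the compounds with values here, no measured step involves a cyanosulfanyl, so the formyl steps give the only guide, and removing that group is expected to raise the number: an estimated step of a 3.0-fold higher number from compound 3 to compound 4 (0.48 log units; beyond the scatter). Compound 4 is therefore expected to give about 60000 nM, between 15000 nM and 250000 nM.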

Compound 4, half-maximal inhibitory concentration: 20000 nM
Estimate against measurement, compound 4: 3.0-fold (0.48 log units) above; measured number inside the range.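

In this assay, going by these compounds alone, formyl is not the only group at this position that gives a readable number, since replacing it with cyanosulfanyl brings no change at the digits printed from compound 3 to compound 4 (within the scatter). Replacing hydrogen or bromo with cyanosulfanyl also gives large steps, an at least 12-fold lower number from compound 1 to compound 4 (1.09 log units; beyond the scatter) and an at least 12-fold lower number from compound 2 to compound 4 (1.09 log units; beyond the scatter). Their true size remains unknown because these steps start from a limit: the limit of > 250000 nM in this assay, at which 2 of the 4 values shown sit.

The compounds shown leave open whether an amine, a carboxylic acid or a longer chain at this position would also give a readable number. They also leave open whether any group here could bring the number much lower.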